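Fluoro for methyl on the indole of compound 3

The compounds below may be only part of what the source reports. "The series", "measured", "known", "first", "only" and "open" are said of these compounds alone.

Measured compounds in an assay on RPMI-8226 cells for antagonist activity at P2X purinoceptor 7 (Homo sapiens), read by calcium flux; on this read-out lower numbers stand for stronger inhibition and higher numbers for weaker inhibition:
- compound 1 `Cc1ccc(S(=O)(=O)N2CCN(CCCn3c(=O)[nH]c4ccccc43)CC2)cc1`: > 10000 nM, a limit of the assay and not a number.
- compound 2 `c1ccc(-c2nc3ccccc3n2CCCCN2CCN(C(c3ccccc3)c3ccccc3)CC2)cc1`: 1200 nM.
- compound 3 `Cc1cccc2c1ccn2CCCCN1CCN(C(c2ccccc2)c2ccccc2)CC1`: 5300 nM.

Compound 3 carries the highest number among the two numbers given, compound 2 sitting lower; that gap is beyond the scatter. Compound 1 gives only a limit.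

Compound 4 `Fc1ccc2c(ccn2CCCCN2CCN(C(c3ccccc3)c3ccccc3)CC2)c1` differs from compound 3 by a group of 10 heavy atoms (8 carbon, 1 nitrogen, 1 fluorine; one five-membered aromatic ring with 1 hetero atom, one six-membered aromatic ring of carbon only) in place of a group of 10 heavy atoms (9 carbon, 1 nitrogen; one five-membered aromatic ring with 1 hetero atom, one six-membered aromatic ring of carbon only), on a saturated chain carbon, four bonds along the chain from an amine nitrogen in a ring. Both compounds keep the same diphenylmethyl-piperazine and four-carbon chain. The change swaps one ring substituent for another of the same count of heavy atoms, so no step beyond the scatter is expected in this assay; the expected step is a 1.3-fold lower number from compound 3 to compound 4 (0.12 log units; within the scatter). For compound 4 the estimate in this assay is 4000 nM, between 1500 nM and 12000 nM.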

Compound 4, half-maximal inhibitory concentration: 120 nM
The estimate for compound 4 lay 33-fold (1.52 log units) above the measured number; the measured number lies below the stated range.
By their numbers in this assay, from the lowest: compound 4; then compound 2; then compound 3. At a limit, above all of these: compound 1.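

In this assay, within the data shown here, the group on a saturated chain carbon, four bonds along the chain from an amine nitrogen in a ring, is the first place with a readable single-place step. Putting 5-fluoro-1H-indol-1-yl there gives a 44-fold lower number from compound 3 to compound 4 (1.65 log units; beyond the scatter) with the heavy-atom count unchanged, so this place is sensitive to the change. Nothing shown gives a cause for this step.

Open, on these data alone, is whether the fluorine or the loss of the methyl drives the step. The 1H-indol-1-yl, 5-chloro-1H-indol-1-yl and 5-methoxy-1H-indol-1-yl groups would separate these.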